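The source may hold more compounds than are shown below. What is called first, only, known or untested is meant among the compounds shown, and "the series" means these compounds.

Compound 1, `Cn1c(=O)c(C(=O)NCCCCCCN)c(O)c2ccccc21`, is the reference point of this set. In an assay on isolated protein for inhibition of seed linoleate 13S-lipoxygenase-1 (Glycine max), tested at 0.1 mM (on this read-out higher numbers stand for more inhibition at the one concentration tested (going by the name of the read-out) and lower numbers for less inhibition), compound 1 gives 92.1%. Compound 2, `NCCCCCCNC(=O)c1c(O)c2ccccc2n(-c2ccccc2)c1=O`, carries a phenyl in place of the methyl on the aromatic nitrogen, and in this assay compound 2 gives 17.6%; the step of a number 74.5 percentage points lower from compound 1 to compound 2 (beyond the scatter) is large. Compound 3, `Cn1c(=O)c(C(=O)NCCCCCCNC(=O)CCCCC2CCSS2)c(O)c2ccccc21`, extends the amine nitrogen of compound 1 with a group of 11 heavy atoms, and in this assay compound 3 gives 79.1%, a step of a number 13 percentage points lower from compound 1 to compound 3 (beyond the scatter) that is modest. Among the compounds with values here, compound 3 therefore stands second of the three numbers so far, below compound 1 and well above compound 2.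

Compound 4, `O=C(CCCCC1CCSS1)NCCCCCCNC(=O)c1c(O)c2ccccc2n(-c2ccccc2)c1=O`, has not yet been measured. Its difference from compound 3 is phenyl in place of methyl on an aromatic nitrogen. Within the data shown here, the only measured step bearing on this change is the same exchange made on compound 1, and it was large and downward. Compound 4 is therefore expected to show a large downward step a number 69.1 percentage points lower from compound 3 to compound 4 (beyond the scatter) in this assay. Compound 4 is estimated at 10%, within a range from 0% to 35%.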

Compound 4, a percentage reported as inhibition, at one concentration (the size of the read-out at that concentration, not a potency): 64%
Estimate against measurement, compound 4: 54 percentage points below; measured number above the stated range.
By their numbers in this assay, from the lowest: compound 2; then compound 4; then compound 3; then compound 1.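

In this assay, the exchange of methyl for phenyl on the aromatic nitrogen does not carry a fixed cost, as the step of a number 15.1 percentage points lower from compound 3 to compound 4 (beyond the scatter) is modest beside the large drop seen with the free amine: the same change on two cores in this assay, a number 74.5 percentage points lower (beyond the scatter) from compound 1 to compound 2 and a number 15.1 percentage points lower (beyond the scatter) from compound 3 to compound 4, 59.4 percentage points apart, beyond the scatter of two such steps Read the other way, the group of 11 heavy atoms on the amine nitrogen, which lowers the number on the methyl pair, gives a number 46.4 percentage points higher from compound 2 to compound 4 (beyond the scatter) on the phenyl pair: the same change on two cores in this assay, a number 13 percentage points lower (beyond the scatter) from compound 1 to compound 3 and a number 46.4 percentage points higher (beyond the scatter) from compound 2 to compound 4, 59.4 percentage points apart, beyond the scatter of two such steps The two changes therefore do not add up across these four compounds, and the size of each depends on the other.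

The compounds shown leave open whether this dependence holds for other groups on the aromatic nitrogen, such as ethyl or benzyl. They also leave open whether a simple acetyl group on the amine nitrogen, or a shorter chain, would give the same rise.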